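A single ring swap in a weakly active series

The source may report more compounds than this note shows. Statements on the series, on what has been measured and on what is new or still open speak of the compounds shown alone.

Of the compounds shown here, two have so far been measured in a functional assay on BJAB cells (Homo sapiens) for antiproliferative activity, with a stated time of 4 days; a higher number here means that more compound is needed for the effect, a lower number that less compound is needed. Compound 1 `CCSc1sc(-n2nc(C)c(Cc3ccccc3[N+](=O)[O-])c2C(=O)O)nc1-c1ccc(Cl)c(Cl)c1` gives 59000 nM in this assay. Compound 2 `Cc1nn(-c2nc(-c3ccc(Cl)c(Cl)c3)c(SC(C)C)s2)c(C(=O)O)c1-c1cncc(C#N)c1` gives 20000 nM in this assay, the lower of the two numbers, and its gap to compound 1 is beyond the usual scatter of repeated measurements. Compounds 1 and 2 differ from each other in more than one place, so no single-change comparison can be drawn from them, and both are weak on this read-out.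

Compound 3 `Cc1nn(-c2nc(-c3ccc(Cl)c(Cl)c3)c(SC(C)C)s2)c(C(=O)O)c1-c1ccncc1` differs from compound 2 in one place: pyridin-4-yl in place of 5-cyanopyridin-3-yl on an aromatic carbon. The triple bond outside aromatic rings is no longer present, and one hydrogen-bond acceptor fewer remains. Among the compounds with values here, nothing measured so far shows what that group contributes, so no firm direction can be read from the data. The step from compound 2 to compound 3 is expected to be a 1.3-fold higher number from compound 2 to compound 3 (0.10 log units; within the scatter), a change that stays within the usual scatter. Compound 3 is therefore estimated to give 25000 nM in this assay, with a likely range from 8000 nM to 80000 nM.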

Compound 3, half-maximal effective concentration: 5900 nM
Estimate against measurement, compound 3: 4.2-fold (0.63 log units) above; the measured number lies below the stated range.
By their numbers in this assay, from the lowest: compound 3; then compound 2; then compound 1.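

In this assay, this aromatic carbon of the five-membered aromatic ring with 2 nitrogen proves responsive to the choice of group: pyridin-4-yl in place of 5-cyanopyridin-3-yl goes with a 3.4-fold lower number from compound 2 to compound 3 (0.53 log units; beyond the scatter) and so moves the read-out by a modest step that lies beyond the scatter. Within the data shown here, this is the first single-change comparison, and it shows that a smaller pyridine group, without the nitrile and with one hydrogen-bond acceptor fewer, is tolerated here and gives the lower number. Nothing measured on these compounds explains the shift, so it stands as an observation without a known cause.

The step combines two changes, the loss of the nitrile and a different attachment point on the pyridine ring, and the compounds shown cannot separate them. As far as these compounds go, how a plain pyridin-3-yl group or a phenyl ring would read at this position remains open, as does whether the same step would hold with the ethylthio group of compound 1 in place of the isopropylthio group.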